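From a Limit Value to a Carbamoylmethoxy Compound

The compounds below may be only part of what the source reports. "The series", "measured", "known", "first", "only" and "open" are said of these compounds alone.

Compound 3 (`CCOC(=O)c1[nH]c(-c2cccc(C#N)c2)nc1C`) gives > 30000 nM in a functional assay on a cell-free system (plasma, Oryctolagus cuniculus) for inhibition, with stated times of 5 min, 1 min and 6 min (a lower number here means a stronger inhibitor, a higher number a weaker inhibitor), as a limit of the assay, not a number. Compound 4 (`CCOC(=O)c1c(C)nc(-c2cccc(C#N)c2)n1OCC(N)=O`) differs from it by carrying carbamoylmethoxy in place of hydrogen on an aromatic nitrogen. Among the measured compounds shown here, no measured pair shows this change directly, so the guidance is only indirect. In this assay compound 1 (`CCOC(=O)c1c(C)nc(-c2ccccc2C#N)n1OC`) gives 14900 nM and compound 2 (`CCOC(=O)c1c(C)nc(-c2ccc(C#N)cc2)n1OC`) gives 13400 nM as values within the usual scatter of each other, and both also carry a group on that aromatic nitrogen. On this indirect ground, a modest move towards stronger inhibition is expected, with an at least 2.7-fold lower number from compound 3 to compound 4 (0.43 log units; beyond the scatter) as the estimated step. Compound 4 is expected at 11000 nM with an estimated range of (3000 nM to 30000 nM).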

Compound 4, half-maximal inhibitory concentration: > 30000 nM
Compound 4 ended at the assay's limit; the forecaster's own chance of this, stated with the estimate: 25%; middle value at least 2.7-fold (0.43 log units) from the limit.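

Among the compounds shown here, compound 3 and compound 4 both stand at the limit of this assay, so no step between them can be read: the limit of > 30000 nM in this assay, at which 2 of the 4 values shown sit. The compounds shown leave open whether carbamoylmethoxy in place of hydrogen on an aromatic nitrogen changes inhibition at all.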